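Replacing the phenylsulfonyl group of compound 1

A few compounds are considered here, and "the series" means these few. Any claim that something is new, unique, unknown or untested is made for them only; others in the source may bear on it.

In an ADME assay on microsomes from liver (Rattus norvegicus) for metabolic stability, read by HPLC, using NADPH (on this read-out higher numbers stand for a longer-lived compound and lower numbers for a shorter-lived compound), compound 1 `CCN(CC)CCNC(=O)c1ccc(C(CC)(CC)c2ccc(OCS(=O)(=O)c3ccccc3)c(C)c2)n1CC` gives 1.04 h. Compound 2 `CCn1c(C(=O)N[C@@H](C)CO)ccc1C(CC)(CC)c1ccc(OCS(=O)(=O)c2ccccc2)c(C)c1` gives 0.729 h, and compound 3 `CCn1c(C(=O)N[C@H](CO)C(C)C)ccc1C(CC)(CC)c1ccc(OCS(=O)(=O)c2ccccc2)c(C)c1` gives 0.772 h. These three numbers lie within the usual scatter of one another, so compound 1 holds no real lead over the other two.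

Compound 4 `CCN(CC)CCNC(=O)c1ccc(C(CC)(CC)c2ccc(OCSC)c(C)c2)n1CC` has not been measured yet. It differs from compound 1 in one place: methylsulfanyl in place of phenylsulfonyl on a saturated chain carbon bound to an oxygen on an aromatic ring. In words, methylsulfanyl stands in place of phenylsulfonyl.

The measured steps change only the group on an amide-type nitrogen. They are a 1.4-fold lower number from compound 1 to compound 2 (0.15 log units; within the scatter) and a 1.3-fold lower number from compound 1 to compound 3 (0.13 log units; within the scatter), and a 1.1-fold higher number from compound 2 to compound 3 (0.02 log units; within the scatter) adds a smaller change to that same group. All three stay within the scatter, but none touches the phenylsulfonyl, so they offer only indirect guidance on this swap.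

With no direct evidence, the expected step is no larger than the scatter, and it is estimated as a 1.4-fold lower number from compound 1 to compound 4 (0.14 log units; within the scatter). The half-life of compound 4 is estimated at 0.75 h, with an expected range of 0.25 h to 1.7 h.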

Compound 4, half-life: 0.954 h
Estimate against measurement, compound 4: 1.3-fold (0.10 log units) below; the range from low to high includes it.
By their numbers in this assay, from the lowest: compounds 2, 3, 4 and 1 (each within the scatter of the next).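

Going by these compounds alone, the earlier compounds changed only the group on the amide-type nitrogen, whereas this is the first step at a saturated chain carbon bound to an oxygen on an aromatic ring, and in this assay it reads a 1.1-fold lower number from compound 1 to compound 4 (0.04 log units; within the scatter). For this pair, the half-life stays within the scatter when phenylsulfonyl, with 9 heavy atoms and an aromatic ring, gives way to methylsulfanyl, with 2 heavy atoms and no ring. Nothing measured here accounts for this result.

The aromatic ring and the two oxygens leave together in this swap, so the compounds shown cannot separate them; methylsulfonyl or phenylsulfanyl would test each change alone. Also open, going by these compounds, is whether methylsulfanyl gives the same result alongside the amide groups of compound 2 and compound 3.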